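Sirtuin-6 series: amide-linked benzoic acids, step to compound 4

The source may hold more compounds than are shown below. What is called first, only, known or untested is meant among the compounds shown, and "the series" means these compounds.

Measured so far:
compound 1 `CCC(=O)Nc1ccc(C(=O)Nc2ccc(C(=O)O)c(O)c2)cc1` gives 70%
compound 2 `O=C(O)c1cccc(NC(=O)c2cccc(N3C(=O)CCS3(=O)=O)c2)c1` gives 5%
compound 3 `O=C(O)c1cccc(NC(=O)c2cccc(NC(=O)c3cccs3)c2)c1` gives 39%

All three numbers come from an assay on isolated protein for inhibition of NAD-dependent protein deacylase sirtuin-6 (Homo sapiens), read by fluorescence, tested at 200 uM; on this read-out lower numbers stand for less inhibition and higher numbers for more inhibition at the one concentration tested (going by the name of the read-out). Compound 3 stands second highest of the three in this assay: compound 1 sits higher and compound 2 lower, both gaps beyond the scatter. For the measured compounds named here, the one step computed so far, a number 34 percentage points higher from compound 2 to compound 3 (beyond the scatter), exchanges one five-membered ring for another on an aromatic carbon and is large.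

Compound 4 `O=C(Cc1cccs1)Nc1cccc(C(=O)Nc2cccc(C(=O)O)c2)c1` is not yet measured. It differs from compound 3 only as follows: (thiophen-2-yl)methyl in place of thiophen-2-yl on a carbonyl carbon. The (thiophen-2-yl)methyl takes the place of the thiophen-2-yl on the carbonyl carbon whose other neighbour is an amide-type nitrogen, so the ring itself stays the same and one carbon is added between ring and carbonyl. Going by the values given here, no measured step covers such an insertion; the step from compound 2 to compound 3 changes the ring, not its spacing, and gives no direct guide. With nothing beyond the scatter to point either way, a step in this assay of a number 4 percentage points lower from compound 3 to compound 4 (within the scatter) is expected, within the scatter. Compound 4 is therefore estimated at 35%, with a range from 15% to 55%.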

Compound 4, a percentage reported as inhibition, at one concentration (the size of the read-out at that concentration, not a potency): "not active" (no number reported)
Nothing numeric was reported for compound 4; the estimate stays without a comparison.
By their numbers in this assay, from the lowest: compound 2; then compound 3; then compound 1.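

For the compounds shown here, compound 4 is reported only as "not active" in this assay and carries no number, so no step from compound 3 to compound 4 can be read. No supporting data bear on this result. Going by these compounds, how much inhibition changes numerically with (thiophen-2-yl)methyl in place of thiophen-2-yl remains open.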